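Second Trifluoromethyl Group and Macrophage Cytotoxicity

The source may hold more compounds than are shown below. What is called first, only, known or untested is meant among the compounds shown, and "the series" means these compounds.

Compound 1 `Cc1cc(NC(=O)c2cc(C(F)(F)F)cc(C(F)(F)F)c2)ccc1NS(C)(=O)=O`: in an ADME assay on RAW264.7 cells (Mus musculus) for cytotoxicity, read by MTT assay, with a stated time of 48 h (on this read-out higher numbers stand for weaker inhibition and lower numbers for stronger inhibition), compound 1 reaches only a limit, > 250000 nM.
Compound 2 `CCS(=O)(=O)Nc1ccc(NC(=O)c2cccc(C(F)(F)F)c2)cc1C`: in this assay compound 2 gives 114000 nM.

For the measured compounds named here, compound 2 holds the only real number in this set; the other value is a limit, (the limit of > 250000 nM in this assay, at which 1 of the 2 values shown sits). Compound 3 `CCS(=O)(=O)Nc1ccc(NC(=O)c2cc(C(F)(F)F)cc(C(F)(F)F)c2)cc1C` has not yet been measured. The change is trifluoromethyl in place of hydrogen on an aromatic carbon, so compound 3 carries the two trifluoromethyl groups of compound 1 together with the ethylsulfonamide of compound 2. Going by the values given here, no directly comparable step has been measured, so the expected size rests only on the fact that compound 1, which also bears two trifluoromethyl groups, sits at > 250000 nM. On that basis compound 3 is expected to move toward weaker inhibition, a step of about a 1.6-fold higher number from compound 2 to compound 3 (0.20 log units; within the scatter). The estimate for compound 3 in this assay is 180000 nM, with a range from 70000 nM to 450000 nM.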

Compound 3, half-maximal inhibitory concentration: 124000 nM
Estimate against measurement, compound 3: 1.5-fold (0.16 log units) above, and the stated range covers the measured number.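

Trifluoromethyl in place of hydrogen at this aromatic carbon can now be read directly: in this assay the change gives a 1.1-fold higher number from compound 2 to compound 3 (0.04 log units; within the scatter), so this pair shows no effect of the second trifluoromethyl group that can be told apart from ordinary repeat variation. The other new comparison, methyl in place of hydrogen on the chain carbon bound to the sulfonyl sulfur, gives an at least 2.0-fold lower number from compound 1 to compound 3 (0.30 log units; that floor lies within the scatter). That step is only a floor, because compound 1 stands at a limit of the assay rather than at a number: the limit of > 250000 nM in this assay, at which 1 of the 3 values shown sits.

As far as these compounds go, it remains open whether a different group at this aromatic carbon, such as a nitrile or an amine, would move the number beyond the scatter. How a longer chain on the sulfonyl sulfur, such as propyl, would read in this assay is open too.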